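Replacing a methyl ether with an acetate ester

The source may report more compounds than this note shows. Statements on the series, on what has been measured and on what is new or still open speak of the compounds shown alone.

Of the compounds shown here, three sharing one core have been tested in a functional assay on MDA-MB-231 cells (Homo sapiens) for cytotoxicity, read by MTT assay, with a stated time of 72 h; on this read-out lower numbers stand for an effect already at smaller amounts and higher numbers for an effect only at larger amounts of compound. Compound 1 `CCOc1c(-c2occ(C)c2C(=O)OC)ccc2c(CC)cccc12` carries a methoxycarbonyl group and gives 1.2 ug/mL. Compound 2 `CCOc1c(-c2occ(C)c2CO)ccc2c(CC)cccc12` carries a hydroxymethyl group in its place and gives 1.4 ug/mL, and the step of a 1.2-fold higher number from compound 1 to compound 2 (0.07 log units; within the scatter) lies within the scatter. Compound 3 `CCOc1c(-c2occ(C)c2COC)ccc2c(CC)cccc12` has a methoxymethyl group, and here the assay returned only a limit, > 10 ug/mL, rather than a number (the limit of > 10 ug/mL in this assay, at which 1 of the 3 values shown sits). The two steps leading to it, an at least 8.3-fold higher number from compound 1 to compound 3 (0.92 log units; beyond the scatter) and an at least 7.1-fold higher number from compound 2 to compound 3 (0.85 log units; beyond the scatter), are both beyond the scatter, so compound 3 stands as the weakest of the three measured compounds.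

Compound 4 `CCOc1c(-c2occ(C)c2COC(C)=O)ccc2c(CC)cccc12` differs from compound 3 by acetyl in place of methyl on an oxygen on a saturated carbon. For the measured compounds named here, no measured step makes exactly this change. Going by the values given here, the closest evidence is the step of an at least 7.1-fold higher number from compound 2 to compound 3 (0.85 log units; beyond the scatter), where capping the oxygen with a methyl moved the number up sharply, and the step of an at least 8.3-fold higher number from compound 1 to compound 3 (0.92 log units; beyond the scatter), where the carbonyl-bearing group of compound 1 was the one with the low number. Compound 4 again carries a carbonyl on that side chain, and the step of an at least 3.3-fold lower number from compound 3 to compound 4 (0.52 log units; beyond the scatter) is therefore expected to bring the number back down, though with real uncertainty. The estimate for compound 4 is 3 ug/mL, within a range from 1 ug/mL to 10 ug/mL.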

Compound 4, concentration for half-maximal effect: 4.9 ug/mL
For compound 4 the middle estimate is 1.6-fold (0.21 log units) below the measured one; the measured number falls inside the stated range.
By their numbers in this assay, from the lowest: compounds 1 and 2 (each within the scatter of the next); then compound 4. At a limit, above all of these: compound 3.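

This result shows that a carbonyl in the side chain is not enough on its own to bring back the low numbers. In this assay, the acetoxymethyl group and the methoxycarbonyl group compare as a 4.1-fold higher number from compound 1 to compound 4 (0.61 log units; beyond the scatter), and putting acetyl on the oxygen of the hydroxymethyl group gives a 3.5-fold higher number from compound 2 to compound 4 (0.54 log units; beyond the scatter), so both caps on that oxygen shown here, methyl and acetyl, end above the uncapped group. The change from methoxy to acetoxy gives an at least 2.0-fold lower number from compound 3 to compound 4 (0.30 log units; that floor lies within the scatter), and this floor does not show how large the change really is, because the number on one side of it is only a limit: the limit of > 10 ug/mL in this assay, at which 1 of the 4 values shown sits.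

The compounds shown leave open whether an oxygen is needed on this side chain at all, or whether an amine such as aminomethyl, or a carboxylic acid, at the same place would give numbers like those of compound 1 and compound 2. They also leave open whether a longer chain on the same oxygen, such as propanoyl or butanoyl, would give a number nearer to that of compound 4 or would reach the limit seen for compound 3.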